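The source may report more compounds than this note shows. Statements on the series, on what has been measured and on what is new or still open speak of the compounds shown alone.

Working notes on the series. In a functional assay on MIA PaCa-2 cells (Homo sapiens) for inhibition, read by MTT assay, with a stated time of 7 days (a higher number here means a weaker inhibitor, a lower number a stronger inhibitor), compound 1 `CCN(CC)S(=O)(=O)c1ccc(S(=O)(=O)N2CCC[C@@H](C(=O)N[C@@H]3CCN(C(=O)OC(C)(C)C)C3)C2)cc1` gives 200 nM. Compound 3 `CCN(CC)S(=O)(=O)c1ccc(S(=O)(=O)N2CCC[C@@H](C(=O)NC3CN(C(=O)OC(C)(C)C)C3)C2)cc1` gives 200 nM in this assay, and compound 2 `CCN(CC)S(=O)(=O)c1ccc(S(=O)(=O)N2CCC[C@@H](C(=O)NC3COC3)C2)cc1` gives 2300 nM. Compound 3 therefore stands level with compound 1, the two together at the lowest numbers of the three, with compound 2 well apart: no change at the digits printed from compound 1 to compound 3 (within the scatter), while a 12-fold higher number from compound 1 to compound 2 (1.06 log units; beyond the scatter) and a 12-fold lower number from compound 2 to compound 3 (1.06 log units; beyond the scatter).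

Compound 4 `CCN(CC)S(=O)(=O)c1ccc(S(=O)(=O)N2CCC[C@@H](C(=O)NC3CN(S(C)(=O)=O)C3)C2)cc1` is the next step from compound 3: methylsulfonyl in place of tert-butoxycarbonyl on an amine nitrogen in a ring. For the measured compounds named here, no measured pair changes the group on the azetidine nitrogen; the measured steps only show that the ring size carrying the tert-butoxycarbonyl group is without effect and that replacing the whole tert-butoxycarbonyl-bearing ring by oxetan-3-yl costs much. The nearest guide is thus weak. Going by the values given here, a small upward move in this assay is expected, a 2.0-fold higher number from compound 3 to compound 4 (0.30 log units; within the scatter), with a wide range because the only large step, a 12-fold lower number from compound 2 to compound 3 (1.06 log units; beyond the scatter), concerns loss of the substituted ring rather than a swap on it. Compound 4 is estimated at 400 nM, between 150 nM and 1200 nM.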

Compound 4, half-maximal inhibitory concentration: 2500 nM
Estimate against measurement, compound 4: 6.3-fold (0.80 log units) below; the whole stated range lies below it.
By their numbers in this assay, from the lowest: compounds 1 and 3 (each within the scatter of the next); then compounds 2 and 4 (each within the scatter of the next).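

The group on this amine nitrogen of the four-membered ring matters on its own in this assay: methylsulfonyl in place of tert-butoxycarbonyl gives a 13-fold higher number from compound 3 to compound 4 (1.10 log units; beyond the scatter) and, with the pyrrolidine-bearing compound as the reference, a 13-fold higher number from compound 1 to compound 4 (1.10 log units; beyond the scatter). The step from the oxetane, a 1.1-fold higher number from compound 2 to compound 4 (0.04 log units; within the scatter), does not separate 1-(methylsulfonyl)azetidin-3-yl from oxetan-3-yl on the amide-type nitrogen, so among these four compounds only the two carrying tert-butoxycarbonyl, compound 1 and compound 3, hold the low numbers. Nothing on hand explains this step.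

From the compounds shown here alone, whether the low numbers need the tert-butoxycarbonyl group itself stays open, as an acetyl group, a shorter carbamate such as methoxycarbonyl or the free amine could test that. Going by these compounds, whether methylsulfonyl acts alike on the pyrrolidine nitrogen also stays open.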